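The source may hold more compounds than are shown below. What is called first, only, known or untested is meant among the compounds shown, and "the series" means these compounds.

Compound 3, `Fc1ccc(Nc2cc3[nH]c(-c4cccc(C(F)(F)F)c4)nc3cn2)nc1`, gives 42% in an ADME assay on microsomes from liver (Rattus norvegicus) for metabolic stability, read by LC-MS, with a stated time of 30 min, tested at 0.1 uM (a higher number here means that more of the compound is left, a lower number that less of the compound is left), the lowest of the three numbers as they stand, though its gap to compound 1 lies within the scatter. Compound 1, `COc1cccc(Nc2cc3[nH]c(-c4cccc(C(F)(F)F)c4)nc3cn2)n1`, gives 49%, and compound 2, `FC(F)(F)c1cccc(-c2nc3cnc(Nc4ccncn4)cc3[nH]2)c1`, gives 88%. The steps of a number 7 percentage points lower from compound 1 to compound 3 (within the scatter) and a number 46 percentage points lower from compound 2 to compound 3 (beyond the scatter) frame that position. Compound 4, `N#Cc1ccc(Nc2cc3[nH]c(-c4cccc(C(F)(F)F)c4)nc3cn2)nc1`, differs from compound 3 by cyano in place of fluoro on an aromatic carbon. Among the measured compounds shown here, no measured step bears directly on it: a number 39 percentage points higher from compound 1 to compound 2 (beyond the scatter) and the two steps just named each exchange the whole aryl group on the nitrogen, so they speak only loosely to a change of one group on a retained aryl. A modest rise is expected, a number 13 percentage points higher from compound 3 to compound 4 (beyond the scatter), in this assay. Compound 4 is therefore estimated at 55%, within 30% to 80%.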

Compound 4, percent of the compound remaining: 49%
Compound 4: the middle estimate sits 6 percentage points above what was measured, within the range that was stated.
By their numbers in this assay, from the lowest: compounds 3, 1 and 4 (each within the scatter of the next); then compound 2.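

In this assay the exchange of fluoro for cyano on the aromatic carbon para to a large group moves the number only within the scatter (a number 7 percentage points higher from compound 3 to compound 4 (within the scatter)). The 5-cyanopyridin-2-yl group cannot be told apart from 6-methoxypyridin-2-yl (no change at the digits printed from compound 1 to compound 4 (within the scatter)), while pyrimidin-4-yl still stands well apart from it (a number 39 percentage points lower from compound 2 to compound 4 (beyond the scatter)). No evidence at hand explains these numbers.
As far as these compounds go, whether an amine or a carboxylic acid at this place would move the number beyond the scatter remains open. So does how cyano would behave on the pyrimidin-4-yl group.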